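The source may hold more compounds than are shown below. What is called first, only, known or untested is meant among the compounds shown, and "the series" means these compounds.

Compound 1, `CC(C(=O)N1CCN(c2ccccc2)CC1)N1C(=O)CCC1=O`: 0%
Compound 2, `CC(C(=O)N1CCN(c2ccccc2C(F)(F)F)CC1)N1C(=O)CCC1=O`: 25%

Both compounds were tested in a functional assay on the whole organism (strain Swiss) with Mus musculus as the target, in the maximal electroshock model, with a stated time of 1 h, at a dose of 100 mg/kg by the intraperitoneal route; on this read-out higher numbers stand for a stronger effect at the one dose given and lower numbers for a weaker effect. Going by the values given here, on this read-out compound 1 stands lowest of the two numbers; the only other compound, compound 2, lies higher by a number 25 percentage points higher from compound 1 to compound 2 (beyond the scatter), a modest step brought about by trifluoromethyl in place of hydrogen on an aromatic carbon.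

Compound 3, `CC(C(=O)N1CCN(c2cccc(F)c2)CC1)N1C(=O)CCC1=O`, has not yet been measured in this assay. It differs from compound 1 in one place: fluoro in place of hydrogen on an aromatic carbon. Among the compounds with values here, the single measured step that bears on this change is the one from compound 1 to compound 2, where a different group, trifluoromethyl, entered the same kind of aromatic position and produced a modest rise of a number 25 percentage points higher from compound 1 to compound 2 (beyond the scatter). Fluoro is a smaller group, and no measured pair shows what fluoro alone does here, so any expectation rests on that one step.

Compound 3 is therefore expected to sit somewhat above compound 1, with an estimated step of a number 10 percentage points higher from compound 1 to compound 3 (within the scatter), giving an expected value of 10%, likely between 0% and 35%.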

Compound 3, a percentage reported as activity, at one dose (the size of the read-out at that dose, not a potency): 0%
The estimate for compound 3 lay 10 percentage points above the measured number; measured number inside the range.
By their numbers in this assay, from the lowest: compounds 1 and 3 (each within the scatter of the next); then compound 2.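

In this assay, putting fluoro on an aromatic carbon of the six-membered ring, meta to a large group, gives no change at the digits printed from compound 1 to compound 3 (within the scatter), so the swap from phenyl to 3-fluorophenyl brings no difference that can be told from the usual scatter. Going by these compounds alone, the only earlier step on this ring was a number 25 percentage points higher from compound 1 to compound 2 (beyond the scatter), made with trifluoromethyl, and the new result shows that a higher number does not follow from every group placed on this ring of the core. Nothing available explains why the two steps differ in size.

Compound 2 and compound 3 carry different groups, and the two steps alone cannot show whether the group, its place on the ring or both account for the contrast; trifluoromethyl at the position held by fluoro in compound 3 would separate these two factors. On these data alone, since compound 1 gives 0%, this read-out also has little room to reveal any weakening, and it remains open whether a larger halogen such as chlorine, a methoxy group or an amine at this position would give a number beyond the scatter.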